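The source may report more compounds than this note shows. Statements on the series, on what has been measured and on what is new or still open speak of the compounds shown alone.

Measured in an ADME assay on cells (Homo sapiens) for cytotoxicity; on this read-out lower numbers stand for stronger inhibition and higher numbers for weaker inhibition:
- Compound 1 `Nc1ccn([C@@H]2S[C@H](CO)C=C2F)c(=O)n1`: > 100000 nM
- Compound 2 `Cc1cn([C@@H]2S[C@H](CO)C=C2F)c(=O)nc1O`: > 100000 nM

Compound 2 gives only a limit, > 100000 nM, and not a number. Both measured compounds share one reading, (the limit of > 100000 nM in this assay, at which 2 of the 2 values shown sit).

Compound 3 `O=c1nc(O)ccn1[C@@H]1S[C@H](CO)C=C1F` differs from compound 2 in one place, with hydrogen in place of methyl on an aromatic carbon. Within the data shown here, no measured pair shows this change on its own. In this assay, no step beyond the scatter is expected, given the limit of compound 2, > 100000 nM. The expected change is a number no higher from compound 2 to compound 3 (the limit leaves the size open). For compound 3 the estimate is 100000 nM, with an expected range of 50000 nM to 200000 nM.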

Compound 3, half-maximal inhibitory concentration: > 100000 nM
Compound 3: only a limit was reported (the forecaster's own chance of this, stated with the estimate: 85%); the middle value sits exactly at the limit.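

Compound 1, compound 2 and compound 3 each give only a limit and not a number, so no step between them can be read in this assay: the limit of > 100000 nM in this assay, at which 3 of the 3 values shown sit.

Going by these compounds, whether hydrogen in place of methyl, or hydroxy in place of amino, changes the true value at all stays open.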